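This account rests on a few compounds, and the source may have more. Where it says the series, first, only, none or still open, it means among the compounds named here.

Working notes on the series. In an assay on cells for inhibition of Rho-associated protein kinase 2 (Homo sapiens), read by radiometric assay and 33P incorporation, in the presence of a further agent that is not named here (a lower number here means a stronger inhibitor, a higher number a weaker inhibitor), compound 1 `CC(C)OC(=O)c1cccc(NC(=O)c2cccc(-c3cc(C(=O)Nc4ccncc4F)ccc3CN)c2)c1` gives 7 nM. Compound 2 `NCc1ccc(C(=O)Nc2ccncc2F)cc1-c1cccc(NC(=O)c2cccc(C(=O)O)c2)c1` has only a limit in this assay, namely < 1 nM. This is the limit of < 1 nM in this assay, at which 1 of the 2 values shown sits, so compound 2 stands at the edge of what the assay reports and carries no number of its own; it cannot be ranked against compound 1 beyond saying that both are potent. Compound 3 `NCc1ccc(C(=O)Nc2ccncc2F)cc1-c1cccc(C(=O)Nc2ccccc2)c1` is not yet measured. It differs from compound 2 in one place: phenylcarbamoyl in place of ((3-carboxyphenyl)carbonyl)amino on an aromatic carbon. Among the compounds with values here, no measured pair shows this change, so the expectation rests on the two values shown, with compound 1 at 7 nM as the only numbered point. The step of an at least 10-fold higher number from compound 2 to compound 3 (1.00 log units; beyond the scatter) is expected to be a loss beyond the usual scatter. Compound 3 is estimated at 10 nM, with a range from 2 nM to 50 nM.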

Compound 3, half-maximal inhibitory concentration: < 1 nM
Compound 3 was reported as a limit; the forecaster's own chance of this, stated with the estimate: 10%; middle value at least 10-fold (1.00 log units) from the limit.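

In this assay compound 3 gives a limit, < 1 nM, not a number, so reaching the limit at this aromatic carbon does not depend on ((3-carboxyphenyl)carbonyl)amino; phenylcarbamoyl reaches it as well. The step between compound 2 and compound 3 cannot be read, and the two groups cannot be separated in this assay: the limit of < 1 nM in this assay, at which 2 of the 3 values shown sit. Within the data shown here, the one readable step is an at least 7.0-fold lower number from compound 1 to compound 3 (0.84 log units; beyond the scatter), with hydrogen in place of isopropoxycarbonyl on an aromatic carbon.

On these data alone, how compound 2 and compound 3 truly rank remains unknown, as neither has a number of its own. Also open, as far as these compounds go, is whether an amine or a hydroxyl group in place of phenylcarbamoyl on this aromatic carbon would hold the limit or give a readable value.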